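The source may hold more compounds than are shown below. What is called first, only, known or untested is meant among the compounds shown, and "the series" means these compounds.

Measured compounds:
Compound 1, `CC1=CC[C@H](C(C)C)c2cc(C)c(OC(=O)c3ccc(C)cc3)cc21`, gives 49.6% in a functional assay on PC-3 cells (Homo sapiens) for antiproliferative activity, read by sulforhodamine B assay, with a stated time of 48 h, tested at 50 uM; on this read-out lower numbers stand for less inhibition and higher numbers for more inhibition at the one concentration tested (going by the name of the read-out).
Compound 2, `CC1=CC[C@H](C(C)C)c2cc(C)c(OC(=O)c3ccc(C(F)(F)F)cc3)cc21`, gives 12.3%.
Compound 3, `CC1=CC[C@H](C(C)C)c2cc(C)c(OC(=O)c3cccc(Cl)c3)cc21`, gives 23.4%.

Compound 3 stands second highest of the three: compound 2 sits lower and compound 1 higher, both beyond the scatter. The change to compound 4, `COc1ccc(C(=O)Oc2cc3c(cc2C)[C@@H](C(C)C)CC=C3C)cc1`, is 4-methoxyphenyl in place of 3-chlorophenyl on a carbonyl carbon. For the measured compounds named here, no measured step swaps these same groups. The nearest guides are a number 26.2 percentage points lower from compound 1 to compound 3 (beyond the scatter) and a number 37.3 percentage points lower from compound 1 to compound 2 (beyond the scatter), which show that the aryl group on the carbonyl carbon moves this read-out strongly. Compound 4 carries a 4-methoxyphenyl, a 4-substituted ring like the 4-methylphenyl of compound 1, so a modest rise in this assay from compound 3 is expected, though a step within the scatter is also plausible. Compound 4 is estimated at 35%, between 15% and 55%, an expected step of a number 11.6 percentage points higher from compound 3 to compound 4 (beyond the scatter).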

Compound 4, a percentage reported as inhibition, at one concentration (the size of the read-out at that concentration, not a potency): 60.6%
The estimate for compound 4 lay 25.6 percentage points below the measured number, and the stated range ends below it.
By their numbers in this assay, from the lowest: compound 2; then compound 3; then compound 1; then compound 4.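

In this assay, 4-methoxyphenyl on the carbonyl carbon gives the highest number of the four compounds, well clear of 3-chlorophenyl (a number 37.2 percentage points higher from compound 3 to compound 4 (beyond the scatter)) and of the trifluoromethyl ring (a number 48.3 percentage points higher from compound 2 to compound 4 (beyond the scatter)). Methoxy in place of methyl on the same aromatic carbon also raises the number (a number 11 percentage points higher from compound 1 to compound 4 (beyond the scatter)), so even these two groups are told apart by this read-out. Nothing measured here explains why these swaps move the number.

Still open, as far as these compounds go, is whether a longer chain, such as ethoxy, in place of methoxy would raise the number further. An amine or a carboxylic acid on that aromatic carbon is also untested among the compounds shown.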